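A few compounds are considered here, and "the series" means these few. Any claim that something is new, unique, unknown or untested is made for them only; others in the source may bear on it.

Measured compounds:
Compound 1 `O=C(CN1CN(c2ccccc2)C2(CCN(C(=O)c3ccc(C4CCCCC4)cc3)CC2)C1=O)NCCCCO` gives 10300 nM in an assay on HEK293 cells for displacement of a labelled ligand from NPC1-like intracellular cholesterol transporter 1 (Homo sapiens); on this read-out lower numbers stand for stronger inhibition and higher numbers for weaker inhibition.
Compound 2 `CCOC(=O)C1CCN(C(=O)CN2CN(c3ccccc3)C3(CCN(C(=O)c4ccc(C(C)(C)C)cc4)CC3)C2=O)CC1` gives 3100 nM in this assay.
Compound 3 `COC(=O)CCCNC(=O)CN1CN(c2ccccc2)C2(CCN(C(=O)c3ccc(C4CCCCC4)cc3)CC2)C1=O` gives 2500 nM in this assay.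

Compound 3 has the lowest number of the three, though compound 2 sits within the scatter of it, so the two cannot be ranked; only compound 1 is clearly set apart, with a higher number. Compound 4 `CS(=O)(=O)NCCCNC(=O)CN1CN(c2ccccc2)C2(CCN(C(=O)c3ccc(C4CCCCC4)cc3)CC2)C1=O` has not yet been measured. It differs from compound 3 in one place: methanesulfonamido in place of methoxycarbonyl on a saturated chain carbon, three bonds along the chain from an amide-type nitrogen.

Going by the values given here, one measured step touches the same place. Going a 4.1-fold lower number from compound 1 to compound 3 (0.61 log units; beyond the scatter), a hydroxymethyl, which carries one hydrogen-bond donor, gave way to methoxycarbonyl, which carries none. Compound 4 now reverses part of that move: methanesulfonamido brings one hydrogen-bond donor back. Among the compounds with values here, with only this single step as a guide, compound 4 is expected to drift back toward compound 1, giving a modest rise of a 2.0-fold higher number from compound 3 to compound 4 (0.30 log units; within the scatter) in this assay. Compound 4 is therefore estimated at 5000 nM, with a range from 2000 nM to 12000 nM.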

Compound 4, half-maximal inhibitory concentration: 3800 nM
For compound 4 the middle estimate is 1.3-fold (0.12 log units) above the measured one, within the range that was stated.
By their numbers in this assay, from the lowest: compounds 3, 2 and 4 (each within the scatter of the next); then compound 1.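

In this assay, methanesulfonamido and methoxycarbonyl cannot be told apart on this chain (a 1.5-fold higher number from compound 3 to compound 4 (0.18 log units; within the scatter)), although only methanesulfonamido carries a hydrogen-bond donor. Hydroxymethyl carries a donor too, yet replacing it with methanesulfonamido gives a clear change (a 2.7-fold lower number from compound 1 to compound 4 (0.43 log units; beyond the scatter)), so among compounds 1, 3 and 4, having a donor at this place does not by itself set the number. Nothing available here accounts for these results.

On these data alone, it remains open how a carboxylic acid, an amine or a longer chain would read at this place. As far as these compounds go, it is also open whether the hydrogen on the methanesulfonamido nitrogen matters at all, which a version with a methyl group on that nitrogen could test.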